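The source may report more compounds than this note shows. Statements on the series, on what has been measured and on what is new or still open speak of the compounds shown alone.

Compound 1 `CC(=O)N1N=C(c2cccc([N+](=O)[O-])c2)CC1c1ccccc1` and compound 2 `COc1ccc(C2CC(c3cccc([N+](=O)[O-])c3)=NN2C(C)=O)cc1` share one core, while compound 3 `COc1ccc(C2CC(c3ccco3)=NN2C(C)=O)cc1OC` and compound 4 `COc1cc(OC)c(C2CC(c3ccco3)=NN2C(C)=O)cc1OC` share another; the difference between the two cores is not broken down here. In a functional assay on HEp-2 cells (Homo sapiens) for cytotoxicity, read by sulforhodamine B assay, with a stated time of 48 h (on this read-out higher numbers stand for weaker inhibition and lower numbers for stronger inhibition), compound 1 gives 8930 nM, and compound 2 gives 8210 nM. The change from compound 1 to compound 2 is methoxy in place of hydrogen on an aromatic carbon, and it made a 1.1-fold lower number from compound 1 to compound 2 (0.04 log units; within the scatter). In this assay compound 3 gives 9990 nM. Compound 4 differs from compound 3 by methoxy in place of hydrogen on an aromatic carbon. Going by the values given here, this is the same kind of change as the one between compound 1 and compound 2, but not the same: in compound 2 the new group sits para to a large group, whereas in compound 4 it sits ortho to a large group, meta to a methoxy group and para to a methoxy group. Because the same kind of change produced only a 1.1-fold lower number from compound 1 to compound 2 (0.04 log units; within the scatter), the step expected here is a 1.1-fold lower number from compound 3 to compound 4 (0.04 log units; within the scatter), resting on that single earlier step alone. In this assay compound 4 is therefore estimated at 9200 nM, expected to fall between 4600 nM and 18500 nM.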

Compound 4, half-maximal inhibitory concentration: 6690 nM
The estimate for compound 4 lay 1.4-fold (0.14 log units) above the measured number, within the range that was stated.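

In this assay, the added methoxy group gave a 1.5-fold lower number from compound 3 to compound 4 (0.17 log units; within the scatter), so on this second core, as on the first, the change moved the number by no more than repeated measurements would. Set side by side, the two steps cannot be told apart: the same change on two cores in this assay, a 1.1-fold lower number (0.04 log units; within the scatter) from compound 1 to compound 2 and a 1.5-fold lower number (0.17 log units; within the scatter) from compound 3 to compound 4, 1.4-fold (0.14 log units) apart, within the scatter of two such steps This shows that, for these two pairs, nothing separates the effect of the change on one core from its effect on the other, but it does not prove that the effects are identical, and it does not show that the change has a real effect on either core, nor that it would carry over to every position, as the new group does not sit in the same place on the ring in the two pairs.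

The compounds shown leave open whether an amine, a carboxylic acid or a longer chain such as butoxy in place of the methoxy group would move the number beyond the scatter. They also leave open how the same methoxy change would behave on a third core.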